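The source may hold more compounds than are shown below. What is called first, only, known or untested is meant among the compounds shown, and "the series" means these compounds.

Among the measured compounds shown here, compound 1 `CC1(c2ccccc2)CC(=O)N(CC(=O)N2CCOCC2)C1=O` sets the only number here: in a functional assay on the whole organism (strain CD-1) with Mus musculus as the target, in the maximal electroshock model, with a stated time of 0.5 h (on this read-out lower numbers stand for an effect already at smaller amounts and higher numbers for an effect only at larger amounts of compound), compound 1 gives 300 mg/kg. Compound 2 `CC1(c2ccccc2)CC(=O)N(CC(=O)N2CCN(c3ccccc3Cl)CC2)C1=O` stands differently, since in this assay compound 2 is reported as "not active" (no number reported), so no single number places it on the dose scale. Compound 3 `CC1(c2ccccc2)CC(=O)N(CC(=O)N2CCN(c3cccc(C(F)(F)F)c3)CC2)C1=O` is made from compound 2 by 3-(trifluoromethyl)phenyl in place of 2-chlorophenyl on an amine nitrogen in a ring. No measured step of this kind exists among these compounds, so the direction and size of the move are open. Because compound 2 shows "not active" (no number reported), compound 3 is expected to need a high dose as well. Compound 3 is estimated at 300 mg/kg, within a range from 100 mg/kg to 1000 mg/kg.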

Compound 3, minimum effective dose: 300 mg/kg
The estimate for compound 3 equals the measured number at the digits printed, within the range that was stated.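

Among the compounds shown here, compound 2 has no number on the dose scale, and no step to compound 3 can be read from it. What replacing 2-chlorophenyl with 3-(trifluoromethyl)phenyl does to the dose stays open, and no measurement here offers an explanation.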